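Benzyl replaces isopentyl on the sulfonamide nitrogen

The compounds below may be only part of what the source reports. "The series", "measured", "known", "first", "only" and "open" are said of these compounds alone.

The measured compounds:
Compound 1, `CC(C)OC(=O)CN(c1cccc(Cl)c1)S(=O)(=O)c1cccc(NC(=O)CCc2ccccc2)c1` — in a functional assay on aorta for antagonist activity at Voltage-gated L-type calcium channel (Rattus norvegicus) (on this read-out lower numbers stand for stronger inhibition and higher numbers for weaker inhibition), compound 1 gives only a limit, > 30000 nM.
Compound 2, `CC(C)OC(=O)CN(c1cccc(Cl)c1)S(=O)(=O)c1cccc(NC(=O)CN(C)C(=O)OCc2ccccc2)c1` — compound 2 gives 15000 nM.
Compound 3, `CC(C)CCCN(c1cccc(Cl)c1)S(=O)(=O)c1cccc(NC(=O)CN(C)C(=O)OCc2ccccc2)c1` — compound 3 gives 12000 nM.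

Compound 3 holds the lowest of the two numbers, but the step of a 1.3-fold lower number from compound 2 to compound 3 (0.10 log units; within the scatter) is within the scatter, so it cannot be called the more potent of the pair. The step of an at least 2.0-fold lower number from compound 1 to compound 2 (0.30 log units; that floor lies within the scatter) rests on a limit for compound 1 and so only sets a floor, and that floor itself lies within the scatter.

Compound 4, `CN(CC(=O)Nc1cccc(S(=O)(=O)N(Cc2ccccc2)c2cccc(Cl)c2)c1)C(=O)OCc1ccccc1`, is not yet measured. It differs from compound 3 by phenyl in place of isopentyl on a saturated chain carbon bound to a sulfonamide nitrogen; read one bond further out, the change is 4-methylpentyl to benzyl. Among the compounds with values here, no measured step touches this exact change. Within the data shown here, the only step at the same place, isopentyl for isopropoxycarbonyl, moved the number by a 1.3-fold lower number from compound 2 to compound 3 (0.10 log units; within the scatter), within the scatter, so no shift beyond the scatter is expected here either. Compound 4 is therefore expected to give about 10000 nM, between 4000 nM and 30000 nM, a step of a 1.2-fold lower number from compound 3 to compound 4 (0.08 log units; within the scatter).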

Compound 4, half-maximal inhibitory concentration: 12000 nM
Compound 4: middle estimate off by 1.2-fold (0.08 log units), on the low side; measured number inside the range.
By their numbers in this assay, from the lowest: compounds 3, 4 and 2 (each within the scatter of the next). At a limit, above all of these: compound 1.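

Within the data shown here, at the place on a saturated chain carbon bound to a sulfonamide nitrogen, an aromatic ring enters for the first time, and in this assay the step is no change at the digits printed from compound 3 to compound 4 (within the scatter). The comparison with the isopropoxycarbonyl compound gives a 1.3-fold lower number from compound 2 to compound 4 (0.10 log units; within the scatter), so isopropoxycarbonyl, isopentyl and benzyl cannot be told apart at this place on this read-out. Compound 1 alone remains at a limit rather than a number: the limit of > 30000 nM in this assay, at which 1 of the 4 values shown sits.

On these data alone, whether a tertiary amine or a carboxylic acid carried on this chain would move the number beyond the scatter remains open. As far as these compounds go, compound 2, compound 3 and compound 4 all carry (benzyloxycarbonyl)(methyl)amino, so it also remains open whether these groups would still read alike with a different group in its place.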